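From phenyl to naphthalen-1-yl on one aromatic carbon

A few compounds are considered here, and "the series" means these few. Any claim that something is new, unique, unknown or untested is made for them only; others in the source may bear on it.

Compound 1 `COc1ccc(-c2cc(-c3cc(OC)c(OC)c(OC)c3)nc(-c3ccccc3)n2)c(OC)c1` gives > 25000 nM as a limit of the assay, not a number
Compound 2 `COc1cc(-c2cc(-c3ccccc3)nc(-c3ccccc3)n2)cc(OC)c1OC` gives 9950 nM as a measured number

Among the measured compounds shown here, in a functional assay on HCT-116 cells (Homo sapiens) for inhibition, read by MTT assay, with a stated time of 48 h (on this read-out lower numbers stand for stronger inhibition and higher numbers for weaker inhibition), compound 2 gives 9950 nM as the only true number so far. Compound 1 gives > 25000 nM as a limit only.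

The next compound, compound 3 `COc1cc(-c2cc(-c3cccc4ccccc34)nc(-c3ccccc3)n2)cc(OC)c1OC`, differs from compound 2 in one group: naphthalen-1-yl in place of phenyl on an aromatic carbon.

For the measured compounds named here, one measured step bears on this, since it changes the same aromatic carbon: an at least 2.5-fold lower number from compound 1 to compound 2 (0.40 log units; beyond the scatter) with phenyl in place of 2,4-dimethoxyphenyl. That step starts from a limit, and the group it removes is not the one entering now, so it is a weak guide. A larger group did go with the higher reading there, but one pair proves no rule. In this assay no clear shift is therefore expected, with a slight move to weaker inhibition at most.

The step expected here is a 1.1-fold higher number from compound 2 to compound 3 (0.04 log units; within the scatter) as a rough estimate. For compound 3 the estimate is 11000 nM with 3000 nM to 30000 nM as the expected range.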

Compound 3, half-maximal inhibitory concentration: 4930 nM
Estimate against measurement, compound 3: 2.2-fold (0.35 log units) above; the range from low to high includes it.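

In this assay, this aromatic carbon can carry naphthalen-1-yl, with its two six-membered aromatic rings of carbon only, in place of phenyl, and the reading stays within the usual scatter: a 2.0-fold lower number from compound 2 to compound 3 (0.30 log units; within the scatter) is too small a step to separate the two compounds. A bigger group on this carbon therefore need not go with weaker inhibition, as 2,4-dimethoxyphenyl and naphthalen-1-yl, both bigger than phenyl, part ways, with an at least 5.0-fold lower number from compound 1 to compound 3 (0.70 log units; beyond the scatter). That step begins at compound 1, whose value is a limit and not a number, so its true size stays unknown: the limit of > 25000 nM in this assay, at which 1 of the 3 values shown sits.

The compounds shown leave open whether the reading at this carbon depends on how the added ring is attached, as naphthalen-2-yl would show, or on a ring containing nitrogen, such as pyridin-3-yl. They also leave open which of the two methoxy groups of 2,4-dimethoxyphenyl goes with the weak reading of compound 1, a question that 4-methoxyphenyl or 2-methoxyphenyl on the same carbon could help to answer.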